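A few compounds are considered here, and "the series" means these few. Any claim that something is new, unique, unknown or untested is made for them only; others in the source may bear on it.

Compound 3 `Cc1ccc(-n2cc(CSC(=S)N3CCN(C(=O)OC(C)(C)C)CC3)nn2)cc1` has the highest of the two numbers obtained in a functional assay on ECa-109 cells (Homo sapiens) for inhibition, read by MTT assay, with a stated time of 72 h; on this read-out lower numbers stand for stronger inhibition and higher numbers for weaker inhibition. Its nearest neighbour is compound 2 `COc1ccc(Cn2cc(CSC(=S)N3CCN(C(=O)OCc4ccccc4)CC3)nn2)cc1`, which gives 58300 nM, while compound 3 gives 114000 nM; the two lie within the scatter of each other. Compound 1 `CC(C)(C)OC(=O)N1CCN(C(=S)SCc2cn(-c3ccccc3F)nn2)CC1` reaches only a limit in this assay, > 128000 nM. Among the compounds with values here, the single measured step at the same position, an at least 1.1-fold lower number from compound 1 to compound 3 (0.05 log units; that floor lies within the scatter), stays within the scatter. Compound 4 `COc1ccc(Cn2cc(CSC(=S)N3CCN(C(=O)OC(C)(C)C)CC3)nn2)cc1` arises from compound 3 through (4-methoxybenzyl in place of 4-methylphenyl on an aromatic nitrogen). Compound 2 also carries 4-methoxybenzyl on an aromatic nitrogen but differs from compound 4 elsewhere, so only its value and that of compound 3 can be compared. Within the data shown here, with the one related step flat, no change beyond the scatter is expected, a 1.5-fold lower number from compound 3 to compound 4 (0.18 log units; within the scatter). Compound 4 is therefore estimated at 75000 nM, between 30000 nM and 180000 nM.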

Compound 4, half-maximal inhibitory concentration: 36800 nM
Beside the measured number, compound 4's estimate is 2.0-fold (0.31 log units) above it; the measured number falls inside the stated range.
By their numbers in this assay, from the lowest: compounds 4, 2 and 3 (each within the scatter of the next, the first and the last beyond it). At a limit, above all of these: compound 1.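

At the aromatic nitrogen, this position now shows its first change beyond the scatter, with 4-methoxybenzyl in place of 4-methylphenyl: a 3.1-fold lower number from compound 3 to compound 4 (0.49 log units; beyond the scatter). Tert-butyl in place of benzyl on an oxygen next to a carbonyl group stays flat: a 1.6-fold lower number from compound 2 to compound 4 (0.20 log units; within the scatter). 4-Methoxybenzyl in place of 2-fluorophenyl gives only a floor, since compound 1 stands at a limit, an at least 3.4-fold lower number from compound 1 to compound 4 (0.54 log units; beyond the scatter): the limit of > 128000 nM in this assay, at which 1 of the 4 values shown sits. The compounds shown leave open whether the methoxy group or the benzyl methylene carries the step from 4-methylphenyl, and how a 4-methylbenzyl, a 4-methoxyphenyl or an amine-bearing benzyl would read.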